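Moving the chlorine on a pyridinyl amide: an estimate

The source may report more compounds than this note shows. Statements on the series, on what has been measured and on what is new or still open speak of the compounds shown alone.

Three compounds have been measured in a functional assay on HepG2 cells (Homo sapiens) for inhibition, read by MTT assay, with a stated time of 72 h; a higher number here means a weaker inhibitor, a lower number a stronger inhibitor:

Compound 1 `Cc1noc(C)c1-c1cnc(N)c(Oc2ccc(C(=O)NC3CC3)cc2)n1` gives 43200 nM.
Compound 2 `Cc1noc(C)c1-c1cnc(N)c(Oc2ccc(C(=O)Nc3ccccc3Cl)cc2)n1` gives only a limit of the assay, > 100000 nM.
Compound 3 `Cc1noc(C)c1-c1cnc(N)c(Oc2ccc(C(=O)Nc3ccc(Cl)cn3)cc2)n1` gives 35600 nM.

Compound 3 holds the lower of the two numbers, yet compound 1 stands close by: a 1.2-fold lower number from compound 1 to compound 3 (0.08 log units; within the scatter) lies within the scatter. The other step, an at least 2.8-fold lower number from compound 2 to compound 3 (0.44 log units; beyond the scatter), is beyond the scatter, although for compound 2 only a limit is known (the limit of > 100000 nM in this assay, at which 1 of the 3 values shown sits).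

Compound 4 `Cc1noc(C)c1-c1cnc(N)c(Oc2ccc(C(=O)Nc3cc(Cl)ccn3)cc2)n1` differs from compound 3 in one place only: 4-chloropyridin-2-yl in place of 5-chloropyridin-2-yl on an amide-type nitrogen. The two groups hold the same atoms, joined differently. Within the data shown here, no measured step exchanges one chloropyridinyl group for another; the nearest comparisons are a 1.2-fold lower number from compound 1 to compound 3 (0.08 log units; within the scatter) and an at least 2.8-fold lower number from compound 2 to compound 3 (0.44 log units; beyond the scatter), which swap in the whole group rather than rearrange it. Among the measured compounds shown here, with such a small change and no direct precedent, the expected step in this assay is a 1.1-fold higher number from compound 3 to compound 4 (0.05 log units; within the scatter), that is, none beyond the scatter. Compound 4 is therefore estimated at 40000 nM, with a range from 15000 nM to 100000 nM.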

Compound 4, half-maximal inhibitory concentration: > 100000 nM
Compound 4: only a limit was reported (the forecaster's own chance of this, stated with the estimate: 20%); middle value at least 2.5-fold (0.39 log units) away from the limit.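

In this assay, among these compounds, the place of the chlorine on the pyridine ring matters, even though both groups hold the same atoms: an at least 2.8-fold higher number from compound 3 to compound 4 (0.44 log units; beyond the scatter) is the first measured step that only rearranges this group. Compound 4 gives only a limit of the assay, > 100000 nM. The 5-chloropyridin-2-yl group stays within the scatter of cyclopropyl, with a 1.2-fold lower number from compound 1 to compound 3 (0.08 log units; within the scatter), while the 4-chloropyridin-2-yl group does not, with an at least 2.3-fold higher number from compound 1 to compound 4 (0.36 log units; beyond the scatter).

The step from compound 2 to compound 4 cannot be read, because both carry only a limit: the limit of > 100000 nM in this assay, at which 2 of the 4 values shown sit. Also open, as far as these compounds go, is what a plain pyridin-2-yl group without chlorine, or a methoxy group in place of the chlorine, would give.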